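Dichlorophenyl in place of fluoromethylphenyl on the sulfonyl

A few compounds are considered here, and "the series" means these few. Any claim that something is new, unique, unknown or untested is made for them only; others in the source may bear on it.

Two close analogues have been measured. In an assay on isolated protein for displacement of a labelled ligand from metabotropic glutamate receptor 5 (Homo sapiens), with a stated time of 60 min, tested at 1 uM (on this read-out lower numbers stand for less inhibition and higher numbers for more inhibition at the one concentration tested (going by the name of the read-out)), compound 2 `Cc1ccc(S(=O)(=O)c2cnc3c(F)cccc3c2N2CCC(C)CC2)cc1F` gives 93%, and compound 1 `COc1ccc2ncc(S(=O)(=O)c3ccc(Cl)cc3)c(N3CCC(C)CC3)c2c1` gives 91%; the two numbers lie within the scatter of each other, so compound 2 stands level with compound 1 rather than apart from it. Compound 3 `CC1CCN(c2c(S(=O)(=O)c3ccc(Cl)c(Cl)c3)cnc3c(F)cccc23)CC1` is not yet measured. It differs from compound 2 in one place: 3,4-dichlorophenyl in place of 3-fluoro-4-methylphenyl on a sulfonyl sulfur. No measured step of this kind exists among these compounds. Compound 3 is expected to give about 90%, between 78% and 98%. This estimate means a number 3 percentage points lower from compound 2 to compound 3 (within the scatter), expected to fall within the scatter.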

Compound 3, a percentage reported as inhibition, at one concentration (the size of the read-out at that concentration, not a potency): 95%
Compound 3: middle estimate off by 5 percentage points, on the low side; low and high end bracket the measured number.
By their numbers in this assay, from the lowest: compounds 1, 2 and 3 (each within the scatter of the next).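

In this assay the exchange of 3-fluoro-4-methylphenyl for 3,4-dichlorophenyl on the sulfonyl sulfur gives a number 2 percentage points higher from compound 2 to compound 3 (within the scatter) and so leaves compound 3 level with compound 2. Within the data shown here, this is the first single change read at this place, and it shows that two chlorine atoms can stand in for the fluorine and methyl with no difference beyond the scatter. Nothing at hand accounts for this result.

From the compounds shown here alone, whether an amine or a carboxylic acid on this phenyl ring would hold the same level stays open. A percentage at one concentration also leaves any difference in potency between compound 2 and compound 3 unknown.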